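Replacing a Methyl on the Oxygen of Compound 2

This account rests on a few compounds, and the source may have more. Where it says the series, first, only, none or still open, it means among the compounds named here.

Compound 1 `COc1cc(/C=C\Cc2cc(O)c3ccoc3c2)cc(OC)c1OC`: 49 nM
Compound 2 `COc1cc(/C=C\Cc2cc(OC)c3ccoc3c2)cc(OC)c1OC`: 7500 nM
Compound 3 `COc1cc(/C=C/Cc2cc(OC)c3ccoc3c2)cc(OC)c1OC`: 75000 nM

In a functional assay on BMEC cells (Bos taurus) for antiproliferative activity (a lower number here means a stronger inhibitor, a higher number a weaker inhibitor), compound 2 gives 7500 nM, the second highest of the three numbers. Compound 4 `COc1cc(/C=C\Cc2cc(OP(=O)(O)O)c3ccoc3c2)cc(OC)c1OC` is not yet measured, and its change is a group of 4 heavy atoms (3 oxygen, 1 phosphorus; no ring) in place of one carbon atom, on an oxygen on an aromatic ring. That change falls on the same oxygen as the step of a 150-fold higher number from compound 1 to compound 2 (2.18 log units; beyond the scatter), which is large. The modest step of a 10-fold higher number from compound 2 to compound 3 (1.00 log units; beyond the scatter) comes with the fact that compounds 2 and 3 differ only in the configuration as drawn, and it bears little here, since compound 4 keeps the Z double bond of compound 2. On these data alone, a large step towards a lower number is therefore expected, though the entering group is untested. The expected step is a 50-fold lower number from compound 2 to compound 4 (1.70 log units; beyond the scatter). For compound 4 the estimated value is 150 nM, with an expected range of 30 nM to 1500 nM.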

Compound 4, half-maximal inhibitory concentration: 340 nM
For compound 4 the middle estimate is 2.3-fold (0.36 log units) below the measured one, and the stated range covers the measured number.
By their numbers in this assay, from the lowest: compound 1; then compound 4; then compound 2; then compound 3.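

In this assay, the group of 3 oxygen and 1 phosphorus atoms on this oxygen on an aromatic ring gives a 22-fold lower number from compound 2 to compound 4 (1.34 log units; beyond the scatter), so a group on this oxygen need not carry the full cost seen with methyl. It does not match the free hydroxyl, with a 6.9-fold higher number from compound 1 to compound 4 (0.84 log units; beyond the scatter), and so places compound 4 between the hydrogen and methyl compounds. Nothing shown here explains this order.

The compounds shown leave open how an ethyl group, an acetyl group or a longer chain carrying an amine would behave on this oxygen. They also leave open whether the phosphorus group would give a similar result on the E double bond.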